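The compounds below may be only part of what the source reports. "The series", "measured", "known", "first", "only" and "open" are said of these compounds alone.

Three compounds have been measured in a functional assay on HeLa cells (Homo sapiens) for inhibition, read by CCK-8 assay, with a stated time of 48 h; on this read-out higher numbers stand for weaker inhibition and lower numbers for stronger inhibition:

Compound 1 `COc1cc(-c2ccnc3cc(-c4c[nH]c5ccccc45)nn23)cc(OC)c1OC` gives 195 nM.
Compound 2 `COc1cc(-c2ccnc3cc(-c4cccc(C#N)c4)nn23)cc(OC)c1OC` gives only a limit, > 10000 nM.
Compound 3 `COc1cc(-c2ccnc3cc(-c4cn(C)c5ccccc45)nn23)cc(OC)c1OC` gives 399 nM.

Compound 3 stands highest of the two numbers shown; its nearest neighbour is compound 1, with a 2.0-fold higher number from compound 1 to compound 3 (0.31 log units; beyond the scatter). Compound 4 `COc1cc(-c2ccnc3cc(-c4ccc5cnn(C)c5c4)nn23)cc(OC)c1OC` is not yet measured; it differs from compound 3 by 1-methyl-1H-indazol-6-yl in place of 1-methyl-1H-indol-3-yl on an aromatic carbon. For the measured compounds named here, two measured steps touch the same aromatic carbon: an at least 51-fold higher number from compound 1 to compound 2 (1.70 log units; beyond the scatter) and an at least 25-fold lower number from compound 2 to compound 3 (1.39 log units; beyond the scatter), both large, though each involves a loss or gain of the whole bicyclic group, which compound 4 keeps. Compound 4 is therefore expected to show only a modest weakening, a 2.0-fold higher number from compound 3 to compound 4 (0.30 log units; within the scatter), and its estimate is 800 nM, with a range from 250 nM to 3000 nM.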

Compound 4, half-maximal inhibitory concentration: 97 nM
The estimate for compound 4 lay 8.2-fold (0.92 log units) above the measured number, and the stated range ends above it.
By their numbers in this assay, from the lowest: compounds 4 and 1 (each within the scatter of the next); then compound 3. At a limit, above all of these: compound 2.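

In this assay the step of a 4.1-fold lower number from compound 3 to compound 4 (0.61 log units; beyond the scatter) shows that this aromatic carbon accepts 1-methyl-1H-indazol-6-yl in place of 1-methyl-1H-indol-3-yl with a gain, so the second ring nitrogen is tolerated here. The step of a 2.0-fold lower number from compound 1 to compound 4 (0.30 log units; within the scatter) leaves no order between those two compounds. The step of an at least 100-fold lower number from compound 2 to compound 4 (2.01 log units; beyond the scatter) starts from a limit and not from a number: the limit of > 10000 nM in this assay, at which 1 of the 4 values shown sits.

The compounds shown leave open whether 1-methyl-1H-indazol-6-yl needs its methyl, and whether an amine or a carboxylic acid on that bicyclic group would be accepted.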